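Replacing the Methoxyphenyl Arm of Compound 1 with Aminofuran

The source may hold more compounds than are shown below. What is called first, only, known or untested is meant among the compounds shown, and "the series" means these compounds.

Measured compounds, all in a functional assay on IMR-32 cells (Homo sapiens) for cytotoxicity; a higher number here means a weaker inhibitor, a lower number a stronger inhibitor:
- compound 1, `COc1ccc(C2C(OC(C)=O)C(=O)N2c2cc(OC)c(OC)c(OC)c2)cc1`: 251 nM
- compound 2, `COc1ccc(C2C(O)C(=O)N2c2cc(OC)c(OC)c(OC)c2)cc1`: 33 nM
- compound 3, `COc1ccc(C2C(O)C(=O)N2c2cc(OC)c(OC)c(OC)c2)cc1N`: 37 nM; 38.3 nM (2 entries)

Compound 1 gives the highest of the two single numbers shown; its nearest neighbour is compound 2, and a 7.6-fold lower number from compound 1 to compound 2 (0.88 log units; beyond the scatter), the change being hydrogen in place of acetyl on an oxygen on a saturated carbon. The repeated entries of compound 3 the several entries of compound 3 in this assay, 37 nM; 38.3 nM (2 entries) show how tightly repeats of this assay agree.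

Compound 4, `COc1cc(N2C(=O)C(OC(C)=O)C2c2ccc(N)o2)cc(OC)c1OC`, differs from compound 1 in another place: 5-aminofuran-2-yl in place of 4-methoxyphenyl on a saturated ring carbon. Within the data shown here, no measured step touches this kind of change; the only measured step concerns the acetyl group, which compound 4 keeps. Without a comparable step, the expected step of a 1.2-fold higher number from compound 1 to compound 4 (0.08 log units; within the scatter) is set near zero, with a wide range. Compound 4 is therefore estimated at 300 nM, between 60 nM and 1500 nM.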

Compound 4, half-maximal inhibitory concentration: > 1000 nM
Compound 4 gave a limit, no number; the forecaster's own chance of this, stated with the estimate: 10%; middle value at least 3.3-fold (0.52 log units) away from the limit.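

Exchanging the whole arm on this saturated ring carbon, 5-aminofuran-2-yl in place of 4-methoxyphenyl, gives an at least 3.9-fold higher number from compound 1 to compound 4 (0.60 log units; beyond the scatter) in this assay, so this position does not accept every aromatic ring equally. From the compounds shown here alone, for compound 4 the result is only a limit, > 1000 nM, so the true size of the step remains unknown. Compound 1, compound 2 and compound 3 all keep the methoxyphenyl ring, so they could not show that exchanging it makes the number higher.

The compounds shown do not separate the change of ring from the added amine: a plain furan-2-yl group or a 4-aminophenyl group on this carbon would tell the two apart. Going by these compounds, it also remains open whether hydrogen in place of acetyl, the change behind a 7.6-fold lower number from compound 1 to compound 2 (0.88 log units; beyond the scatter), would act the same way with the aminofuran arm.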